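Ring substitution on the shared core of compound 1

This account rests on a few compounds, and the source may have more. Where it says the series, first, only, none or still open, it means among the compounds named here.

Compound 1 `O=C1/C(=C/c2ccccc2)Cc2cc(O)ccc21` is the unsubstituted parent of this small set. In an assay on isolated protein for inhibition of Amine oxidase [flavin-containing] B (Homo sapiens), read by fluorescence and spectrophotometry, with a stated time of 20 min (on this read-out lower numbers stand for stronger inhibition and higher numbers for weaker inhibition), compound 1 gives 376 nM, the highest number among the three measured compounds. Compound 2 `O=C1/C(=C/c2cccc(F)c2)Cc2cc(O)ccc21` gives 84 nM and compound 3 `N#Cc1cccc(/C=C2\Cc3cc(O)ccc3C2=O)c1` gives 130 nM; these two values lie within the usual scatter of each other, so no order between them is claimed.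

Compound 4 `N#Cc1ccc(/C=C2\Cc3cc(O)ccc3C2=O)cc1` differs from compound 1 by cyano in place of hydrogen on an aromatic carbon.

Within the data shown here, two measured steps bear on this change. Among the measured compounds shown here, the closest precedent introduces the same group at another aromatic carbon: a 2.9-fold lower number from compound 1 to compound 3 (0.46 log units; beyond the scatter). A different small substituent at an aromatic carbon of the same ring moved the number the same way: a 4.5-fold lower number from compound 1 to compound 2 (0.65 log units; beyond the scatter). Both replacements of ring hydrogen lowered the number beyond the scatter, though only modestly. For the measured compounds named here, for cyano placed para to the large group there is no direct precedent in the set, so the expectation rests on compound 3 and its step of a 2.9-fold lower number from compound 1 to compound 3 (0.46 log units; beyond the scatter), taken as the nearest guide.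

Compound 4 is therefore expected to show a modest lowering in this assay, a step of about a 2.5-fold lower number from compound 1 to compound 4 (0.40 log units; beyond the scatter). Compound 4 is estimated at 150 nM, with a range from 60 nM to 400 nM.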

Compound 4, half-maximal inhibitory concentration: 316 nM
Beside the measured number, compound 4's estimate is 2.1-fold (0.32 log units) below it, within the range that was stated.
By their numbers in this assay, from the lowest: compounds 2 and 3 (each within the scatter of the next); then compounds 4 and 1 (each within the scatter of the next).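

In this assay cyano para to a large group gives a 1.2-fold lower number from compound 1 to compound 4 (0.08 log units; within the scatter) and so leaves the number where the parent stands, whereas cyano at another aromatic carbon gave a 2.9-fold lower number from compound 1 to compound 3 (0.46 log units; beyond the scatter) beyond the scatter. The replacement of ring hydrogen by cyano therefore does not lower the number at every aromatic carbon of this ring, and the lowering seen earlier cannot be read as following from the group alone. Compound 4 is also the first compound in the set that stands within the scatter of compound 1, and the data shown give no measurement that explains the difference between the two cyano placements.

Cyano is the only group shown para to a large group, so it remains open whether this carbon tolerates no gain from any substituent or whether the outcome is particular to cyano. Fluoro, an amine, a methoxy group or a carboxylic acid at this same carbon would separate these readings, and a comparison of such groups across both ring positions would show how far position outweighs the choice of group.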